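The source may hold more compounds than are shown below. What is called first, only, known or untested is meant among the compounds shown, and "the series" means these compounds.

Measured so far in an assay on isolated protein for antagonist activity at Rap guanine nucleotide exchange factor 4 (Homo sapiens), read by fluorescence and cAMP accumulation; on this read-out higher numbers stand for weaker inhibition and lower numbers for stronger inhibition:
compound 1 `Cc1cc(C)c(S(=O)(=O)c2cc(C)c(C)cc2C)c(C)c1`, for which compound 1 gives 700 nM;
compound 2 `CCCCCc1ccc(S(=O)(=O)c2c(C)cc(C)cc2C)cc1`, for which compound 2 reaches only a limit of the assay, > 300000 nM;
compound 3 `Cc1cc(C)c(S(=O)(=O)c2ccc(C3CCCCC3)cc2)c(C)c1`, for which compound 3 likewise reaches only a limit of the assay, > 300000 nM.

Compound 3 therefore stands at the limit of > 300000 nM in this assay, at which 2 of the 3 values shown sit, with no number of its own. For the measured compounds named here, the one single-place step among the measured compounds, a step that the two limits leave unreadable from compound 2 to compound 3, runs between two limits and gives no readable size. Compound 4 `Cc1cc(C)c(S(=O)(=O)c2ccc(I)cc2)c(C)c1` differs from compound 3 by iodo in place of cyclohexyl on an aromatic carbon. Going by the values given here, no measured step bears directly on this change, and the step from compound 2 to compound 3 offers no size to carry over, so no direction can be read from the measured steps alone. The expectation for compound 4 in this assay is therefore broad: compound 4 is estimated at 100000 nM, within 5000 nM to 300000 nM. This estimate implies a step of an at least 3.0-fold lower number from compound 3 to compound 4 (0.47 log units; beyond the scatter), which may again end as a limit rather than a number.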

Compound 4, half-maximal inhibitory concentration: 4000 nM
The estimate for compound 4 lay 25-fold (1.40 log units) above the measured number; the whole stated range lies above it.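

In this assay, for the compounds shown here, the change to iodo on this aromatic carbon gives the first readable steps at this position: an at least 75-fold lower number from compound 3 to compound 4 (1.87 log units; beyond the scatter) and an at least 75-fold lower number from compound 2 to compound 4 (1.87 log units; beyond the scatter). The earlier step between pentyl and cyclohexyl cannot be read, whereas these steps show that the number at this position can shift strongly with the group it carries, with iodo, at 1 heavy atom, giving a measured number. Compound 2 and compound 3, with their larger carbon groups, remain at a limit of the assay: the limit of > 300000 nM in this assay, at which 2 of the 4 values shown sit.

The compounds shown leave open how a bromo, a methoxy or a shorter chain such as ethyl would read at this place. They also cannot separate which feature of iodo accounts for the change, since iodo differs from pentyl and cyclohexyl in both its element and its atom count.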